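The source may hold more compounds than are shown below. What is called first, only, known or untested is meant among the compounds shown, and "the series" means these compounds.

Compound 1 `CC#C[C@@H](Cc1nnn[nH]1)c1ccc(OCc2ccc3sc(F)c(-c4ccccc4C)c3c2)cc1` gives 14 nM in a functional assay on cells for agonist activity at Free fatty acid receptor 1 (Rattus norvegicus), read by FLIPR and calcium flux; a lower number here means that less compound is needed, a higher number that more compound is needed for the effect.
Compound 2 `CC#C[C@@H](Cc1nnn[nH]1)c1ccc(OCc2ccc3scc(-c4cc(OCCOC)ccc4C)c3c2)cc1` gives 26 nM in this assay.
Compound 3 `CC#C[C@@H](Cc1nnn[nH]1)c1ccc(OCc2ccc3sc(C#N)c(-c4ccccc4C)c3c2)cc1` gives 19 nM in this assay.

Compound 2 has the largest number of the three, yet its gaps to compound 3 and to compound 1 both lie within the scatter, so the three compounds cannot be told apart. Compound 4 `CC#C[C@@H](Cc1nnn[nH]1)c1ccc(OCc2ccc3scc(-c4ccccc4C(F)(F)F)c3c2)cc1` is not yet measured. It differs from compound 2 by 2-(trifluoromethyl)phenyl in place of 5-(2-methoxyethoxy)-2-methylphenyl on an aromatic carbon. Within the data shown here, the only measured step, a 1.4-fold higher number from compound 1 to compound 3 (0.13 log units; within the scatter), changes a different position of the shared core and is itself within the scatter. Among the measured compounds shown here, no measured step touches the position changed here, so the expectation is a step of about a 1.0-fold lower number from compound 2 to compound 4 (0.02 log units; within the scatter) in this assay, with no direction beyond the scatter. Compound 4 is therefore estimated at 25 nM, between 8 nM and 80 nM.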

Compound 4, half-maximal effective concentration: 2 nM
The estimate for compound 4 lay 13-fold (1.10 log units) above the measured number; the whole stated range lies above it.
By their numbers in this assay, from the lowest: compound 4; then compounds 1, 3 and 2 (each within the scatter of the next).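

In this assay, the aryl group on this aromatic carbon, two ring bonds from the ring sulfur, proves to matter: the change gives a 13-fold lower number from compound 2 to compound 4 (1.11 log units; beyond the scatter) and so moves the number well beyond the scatter. The earlier compounds shown here showed only differences within the scatter, so they gave no sign that the potency could shift this much. Nothing shown here gives a cause for this step.

The change replaces the methyl and removes the 2-methoxyethoxy chain together with adding trifluoromethyl, so the contribution of each stays unresolved. From the compounds shown here alone, how this aryl group would fare carrying an amine or a carboxylic acid also remains open.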